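Aryl swaps on the shared core

A few compounds are considered here, and "the series" means these few. Any claim that something is new, unique, unknown or untested is made for them only; others in the source may bear on it.

Measured in a physicochemical assay for lipophilicity; a higher number here means a more lipophilic compound, a lower number a more polar compound:
- compound 1 `C[C@H]1CC[C@@H]2[C@@H](OC(=O)[C@]23CC(c2cccc(Cl)c2)N(c2ccccc2)O3)[C@]2(C)C(=O)C=C[C@@]12O`: 3.87
- compound 2 `C[C@H]1CC[C@@H]2[C@@H](OC(=O)[C@]23CC(c2ccccc2Cl)N(c2ccccc2)O3)[C@]2(C)C(=O)C=C[C@@]12O`: 3.87
- compound 3 `C[C@H]1CC[C@@H]2[C@@H](OC(=O)[C@]23CC(c2ccccc2F)N(c2ccccc2)O3)[C@]2(C)C(=O)C=C[C@@]12O`: 3.35

Compound 3 stands lowest of the three. The next structure, compound 4 `COc1cccc(C2C[C@@]3(ON2c2ccccc2)C(=O)O[C@@H]2[C@H]3CC[C@H](C)[C@]3(O)C=CC(=O)[C@@]23C)c1`, carries 3-methoxyphenyl in place of 2-fluorophenyl on a saturated ring carbon. Going by the values given here, no measured compound has a methoxy group, so the evidence is indirect. Fluoro in place of chloro gave a number 0.52 log units lower from compound 2 to compound 3 (beyond the scatter), and 2-fluorophenyl in place of 3-chlorophenyl gave a number 0.52 log units lower from compound 1 to compound 3 (beyond the scatter). 2-chlorophenyl in place of 3-chlorophenyl gave no change at the digits printed from compound 1 to compound 2 (within the scatter). A slight upward step within the scatter is expected in this assay, namely a number 0.10 log units higher from compound 3 to compound 4 (within the scatter). The estimate for compound 4 is 3.45, with an expected range of 3.1 to 3.8.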

Compound 4, partition coefficient: 3.25
Estimate against measurement, compound 4: 0.20 log units above; the measured number falls inside the stated range.
By their numbers in this assay, from the lowest: compounds 4 and 3 (each within the scatter of the next); then compounds 1 and 2 (each within the scatter of the next).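

In this assay, the step from 2-fluorophenyl to 3-methoxyphenyl at this saturated ring carbon is a number 0.10 log units lower from compound 3 to compound 4 (within the scatter), so these two aryl groups cannot be told apart here. Against the chloro compounds the picture differs: 3-methoxyphenyl in place of 2-chlorophenyl gives a number 0.62 log units lower from compound 2 to compound 4 (beyond the scatter), and methoxy in place of chloro on the aromatic carbon gives a number 0.62 log units lower from compound 1 to compound 4 (beyond the scatter). No measurement shown explains these steps. Open, on these data alone, is how an aryl group carrying an amine or a carboxylic acid would read in this assay.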